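Swapping an aryl urea end for a hydroxyethyl urea

The source may hold more compounds than are shown below. What is called first, only, known or untested is meant among the compounds shown, and "the series" means these compounds.

Measured compounds:
compound 1, `COc1ccc(/C(=N/NC(=O)NCCCC(C)Nc2cc(OC)cc3cccnc23)c2ccccc2)cc1`: > 100000 nM
compound 2, `COc1cc(NC(C)CCCNC(=O)NNC(=O)Nc2ccc(Cl)c(C(F)(F)F)c2)c2ncccc2c1`: 15000 nM
compound 3, `O=C(NC(c1ccccc1)c1ccc(Cl)cc1)NC(c1ccccc1)c1ccc(Cl)cc1`: > 100000 nM

Of the compounds shown here, three have been tested in a functional assay on SW-620 cells (Homo sapiens) for inhibition, read by MTT assay, with a stated time of 4 days; on this read-out lower numbers stand for stronger inhibition and higher numbers for weaker inhibition. Compound 1 gives only a limit of the assay, > 100000 nM. Compound 3 likewise reaches only a limit, > 100000 nM. Going by the values given here, compound 2 is the sole compound that returns a number, 15000 nM, so it stands alone among the three as the one with a measured potency. The other two results are the limit of > 100000 nM in this assay, at which 2 of the 3 values shown sit.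

Compound 4, `COc1cc(NC(C)CCCNC(=O)NNC(=O)NCCO)c2ncccc2c1`, is a close relative of compound 2. The change is 2-hydroxyethyl in place of 4-chloro-3-(trifluoromethyl)phenyl on an amide-type nitrogen. Among the compounds with values here, no pair of measured compounds differs in a single place, so no measured step guides the expectation. The step of a 4.0-fold higher number from compound 2 to compound 4 (0.60 log units; beyond the scatter) is nonetheless expected to weaken inhibition beyond the scatter, moving the result toward the limit at which compound 1 and compound 3 sit. Compound 4 is therefore estimated at 60000 nM, with a range from 15000 nM to 100000 nM, and a fair chance that only a limit is reported.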

Compound 4, half-maximal inhibitory concentration: > 100000 nM
Compound 4 ended at the assay's limit; the forecaster's own chance of this, stated with the estimate: 55%; middle value at least 1.6-fold (0.22 log units) away from the limit.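

In this assay, going by these compounds alone, replacing 4-chloro-3-(trifluoromethyl)phenyl with 2-hydroxyethyl on this amide-type nitrogen gives the first readable step between compounds that differ in one place: an at least 6.6-fold higher number from compound 2 to compound 4 (0.82 log units; beyond the scatter). Compound 4 gives > 100000 nM, which is a limit of the assay and not a number, so the step sets only a minimum size for the loss. At this position, the 4-chloro-3-(trifluoromethyl)phenyl end of compound 2 therefore keeps a measurable potency that the 2-hydroxyethyl end does not, and the set now sits largely at one boundary: the limit of > 100000 nM in this assay, at which 3 of the 4 values shown sit.

The compounds shown do not separate the contribution of the aromatic ring from that of its chlorine and trifluoromethyl groups. On these data alone, it also remains open whether a plain phenyl, a longer alkyl chain or a chain ending in an amine at this nitrogen would return a measurable value.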